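Replacing azido with ethyl in compound 3

The source may report more compounds than this note shows. Statements on the series, on what has been measured and on what is new or still open speak of the compounds shown alone.

Compound 1 `[N-]=[N+]=Nc1cc(=O)[nH]c(=O)n1[C@@H]1O[C@H](CO)[C@@H](O)[C@H]1O`: > 50000 nM (a limit)
Compound 2 `Nc1cc(=O)[nH]c(=O)n1[C@@H]1O[C@H](CO)[C@@H](O)[C@H]1O`: > 50000 nM (a limit)
Compound 3 `[N-]=[N+]=Nc1c(F)c(=O)[nH]c(=O)n1[C@@H]1O[C@H](CO)[C@@H](O)[C@H]1O`: 600 nM

Among the measured compounds shown here, in a functional assay on cells (Homo sapiens) for antiproliferative activity, read by WST assay, with a stated time of 3 days (on this read-out higher numbers stand for weaker inhibition and lower numbers for stronger inhibition), compound 3 gives 600 nM, the only true number so far. The other results rest on (the limit of > 50000 nM in this assay, at which 2 of the 3 values shown sit).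

The next compound is compound 4 `CCc1c(F)c(=O)[nH]c(=O)n1[C@@H]1O[C@H](CO)[C@@H](O)[C@H]1O`, with ethyl in place of azido on an aromatic carbon. The fluoro group stays.

For the measured compounds named here, two measured steps bear on this change. Fluoro in place of hydrogen gave an at least 83-fold lower number from compound 1 to compound 3 (1.92 log units; beyond the scatter), a large step, but it happened at another place on the shared core. Amino in place of azido gave a step that the two limits leave unreadable from compound 1 to compound 2, so the one measured replacement of azido gives no size to borrow. Going by the values given here, neither step tests ethyl, and no measured compound carries it.

Among the compounds with values here, compound 3 at 600 nM is the only compound with a readable number, and it is also the only one holding both azido and fluoro. Losing the azido therefore seems more likely to weaken inhibition than to strengthen it, though the size is uncertain. The expected result in this assay is a clear move to a higher number, estimated as a 25-fold higher number from compound 3 to compound 4 (1.40 log units; beyond the scatter). For compound 4 the estimated value is 15000 nM, with an expected range from 1500 nM to 50000 nM.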

Compound 4, half-maximal inhibitory concentration: 1400 nM
Estimate against measurement, compound 4: 11-fold (1.03 log units) above, outside the stated range (below it).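

In this assay, ethyl in place of azido gives a 2.3-fold higher number from compound 3 to compound 4 (0.37 log units; beyond the scatter), a modest step and the first readable size for any replacement at this position. With the fluoro group kept, the azido group can therefore give way to ethyl, a group with no nitrogen, and the result is still a true number rather than a limit. The one earlier replacement of azido, amino in compound 2, could give no such size, because compound 1 and compound 2 both rest on a limit: the limit of > 50000 nM in this assay, at which 2 of the 4 values shown sit.

The compounds shown leave open how a methyl group or a longer chain such as propyl would read at this position with fluoro kept, and so whether the number follows the length of the chain. Also open, as far as these compounds go, is what ethyl does with hydrogen in place of fluoro, the very change that produced such a large step when azido sat at this position.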